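A few compounds are considered here, and "the series" means these few. Any claim that something is new, unique, unknown or untested is made for them only; others in the source may bear on it.

The three measured compounds share one core and differ only in the aryl group on the carbon that is double-bonded to nitrogen. Compound 1 `CN(C)CCn1cnnc1-c1cc(Oc2ccc(NC(=O)N/N=C/c3ccc(Cl)cc3Cl)cc2F)ccn1` carries 2,4-dichlorophenyl there, and in a functional assay on MKN-45 cells (Homo sapiens) for cytotoxicity, read by MTT assay, with a stated time of 72 h (a higher number here means a weaker inhibitor, a lower number a stronger inhibitor), compound 1 gives 750 nM. Compound 2 `CN(C)CCn1cnnc1-c1cc(Oc2ccc(NC(=O)N/N=C/c3c[nH]c4ccccc34)cc2F)ccn1` carries 1H-indol-3-yl, and in this assay compound 2 gives 790 nM; the step of a 1.1-fold higher number from compound 1 to compound 2 (0.02 log units; within the scatter) lies within the scatter. Compound 3 `COc1ccc(/C=N/NC(=O)Nc2ccc(Oc3ccnc(-c4nncn4CCN(C)C)c3)c(F)c2)c(OC)c1OC` carries 2,3,4-trimethoxyphenyl, and in this assay compound 3 gives 2020 nM, the highest number of the three, with the steps of a 2.7-fold higher number from compound 1 to compound 3 (0.43 log units; beyond the scatter) and a 2.6-fold higher number from compound 2 to compound 3 (0.41 log units; beyond the scatter) both beyond the scatter.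

Compound 4 `CN(C)CCn1cnnc1-c1cc(Oc2ccc(NC(=O)N/N=C/c3ccc(F)cc3F)cc2F)ccn1` differs from compound 3 by 2,4-difluorophenyl in place of 2,3,4-trimethoxyphenyl on a carbon with a double bond to nitrogen. The two steps that bear on this change both ran into the trimethoxyphenyl and raised the number modestly, so the reverse move is expected to lower it by a comparable amount; the entering 2,4-difluorophenyl, like the 2,4-dichlorophenyl of compound 1, brings no hydrogen-bond acceptors. Compound 4 is therefore expected to give about 800 nM in this assay, within 400 nM to 1600 nM. The estimated step of a 2.5-fold lower number from compound 3 to compound 4 (0.40 log units; beyond the scatter) is expected to be modest and downward.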

Compound 4, half-maximal inhibitory concentration: 810 nM
Estimate against measurement, compound 4: 1.0-fold (0.01 log units) below, within the range that was stated.
By their numbers in this assay, from the lowest: compounds 1, 2 and 4 (each within the scatter of the next); then compound 3.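

In this assay, the 2,4-difluorophenyl of compound 4 falls with compound 1 and compound 2 rather than with compound 3: the steps of a 1.1-fold higher number from compound 1 to compound 4 (0.03 log units; within the scatter) and a 1.0-fold higher number from compound 2 to compound 4 (0.01 log units; within the scatter) lie within the scatter, while the step of a 2.5-fold lower number from compound 3 to compound 4 (0.40 log units; beyond the scatter) lies beyond it. On this carbon with a double bond to nitrogen, 2,4-difluorophenyl, 2,4-dichlorophenyl and 1H-indol-3-yl cannot be told apart, and among these four compounds only 2,3,4-trimethoxyphenyl stands apart, with the higher number. Nothing at hand accounts for this difference.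

The compounds shown leave open whether a single methoxy group on the phenyl ring would already raise the number or whether the full 2,3,4-trimethoxyphenyl is needed. They also leave open how an unsubstituted phenyl, or a phenyl carrying a carboxylic acid or a dimethylamino group, would read at this carbon.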